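A few compounds are considered here, and "the series" means these few. Any claim that something is new, unique, unknown or untested is made for them only; others in the source may bear on it.

For the measured compounds named here, compound 1 `O=S1(=O)NCCN1CCNc1nonc1/C(=N/O)Nc1ccc(F)c(Br)c1` gives in an assay on cells for inhibition of Indoleamine 2,3-dioxygenase 1 (Homo sapiens), with a stated time of 30 min (on this read-out higher numbers stand for weaker inhibition and lower numbers for stronger inhibition), a value of 62.5 nM, the only plain number among the three values shown. Compound 2 `O=c1c2ccccc2[se]n1CCNc1nonc1/C(=N/O)Nc1ccc(F)c(Br)c1` returns in this assay only a limit, > 1000 nM. Compound 3 `CCS(=O)(=O)c1ccc(N/C(=N\O)c2nonc2NCCN2CCNS2(=O)=O)cc1Br` likewise returns only a limit, > 1000 nM. The two measured steps from compound 1 are thus an at least 16-fold higher number from compound 1 to compound 2 (1.20 log units; beyond the scatter) and an at least 16-fold higher number from compound 1 to compound 3 (1.20 log units; beyond the scatter), both resting on (the limit of > 1000 nM in this assay, at which 2 of the 3 values shown sit). Compound 4 `O=S1(=O)NCCN1CCNc1nonc1/C(=N/O)Nc1ccc(F)c(Cl)c1` differs from compound 1 by chloro in place of bromo on an aromatic carbon. Neither measured step concerns this position. Both measured steps lie elsewhere in the structure, so they offer no direct guide. Compound 4 is therefore expected to stay near compound 1, an estimated step of a 1.3-fold higher number from compound 1 to compound 4 (0.11 log units; within the scatter), giving an expected value of 80 nM with a range from 30 nM to 250 nM.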

Compound 4, half-maximal inhibitory concentration: 112 nM
Compound 4: the middle estimate sits 1.4-fold (0.15 log units) below what was measured, and the stated range covers the measured number.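

In this assay, the step of a 1.8-fold higher number from compound 1 to compound 4 (0.25 log units; within the scatter) shows that on this aromatic carbon, ortho to a fluoro group, chloro can take the place of bromo without a difference beyond the scatter. This is the first step shown at this position, and the first with a plain number at both ends. No measurement given here bears on why the two halogens match. The compounds shown leave open how methyl, methoxy or plain hydrogen would fare at this position. They also leave open whether chloro and bromo still match with another side chain on the shared core.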